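The source may hold more compounds than are shown below. What is called first, only, known or untested is meant among the compounds shown, and "the series" means these compounds.

Measured compounds:
- Compound 1 `O=c1ccc(-c2ccccc2)nn1CCCCNC(=S)Nc1ccc(Cl)cc1`. In a functional assay on the whole organism (stomach) with Rattus norvegicus as the target (a lower number here means that less compound is needed, a higher number that more compound is needed for the effect), compound 1 gives > 100 mg/kg, which is a limit of the assay rather than a number.
- Compound 2 `C/N=C(/NC#N)NCCCCn1nc(N(C)C)ccc1=O`. In this assay compound 2 gives > 100 mg/kg, again only a limit.
- Compound 3 `O=c1ccc(-c2ccccc2)nn1CCCC/N=C(\S)Nc1cccc(F)c1`. In this assay compound 3 gives > 100 mg/kg, also a limit.

Compound 1 thus stands at the limit of > 100 mg/kg in this assay, at which 3 of the 3 values shown sit, and no numbered dose is known for it. Compound 4 `C=CCNC(=S)NCCCCn1nc(-c2ccccc2)ccc1=O` is the compound still to be measured. It differs from compound 1 in one place: allyl in place of 4-chlorophenyl on an amide-type nitrogen. Among the compounds with values here, no pair of measured compounds separated by a single change is available, so the size of this step cannot be read from the data. The expectation for compound 4 is a step that the limit leaves unreadable from compound 1 to compound 4, most likely leaving it at a limit as well. Compound 4 is therefore estimated at 150 mg/kg, with a range from 40 mg/kg to 600 mg/kg.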

Compound 4, dose for half-maximal effect: > 100 mg/kg
Compound 4: no number, only a limit; the forecaster's own chance of this, stated with the estimate: 75%; the middle value is on the limit's open side.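

Within the data shown here, no step from compound 1 to compound 4 can be read, because both results are limits and not numbers: the limit of > 100 mg/kg in this assay, at which 4 of the 4 values shown sit.

The compounds shown leave open what dose of any of them gives the effect in this assay and whether allyl in place of 4-chlorophenyl alters that dose.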